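The compounds below may be only part of what the source reports. "The series", "measured", "known", "first", "only" and "open" are said of these compounds alone.

Measured compounds:
- compound 1, `O=C(Nc1nc2ccccc2s1)c1cn(-c2ccccc2)nc1-c1ccc(F)cc1`: 33400 nM
- compound 2, `O=C(Nc1nc2ccc(Cl)cc2s1)c1cn(-c2ccccc2)nc1-c1ccc(F)cc1`: 45700 nM
- compound 3, `O=C(Nc1nc2ccccc2s1)c1cn(-c2ccccc2)nc1-c1ccc(Cl)cc1`: 39600 nM

All three numbers come from an ADME assay on HEK-293T cells (Homo sapiens) for cytotoxicity, read by MTT assay, with a stated time of 72 h; on this read-out higher numbers stand for weaker inhibition and lower numbers for stronger inhibition. Compound 3 stands second highest of the three: its nearest neighbour is compound 2, its furthest is compound 1, and both gaps are within the scatter, so the three compounds cannot be told apart on this read-out.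

Compound 4, `O=C(Nc1nc2ccc(Cl)cc2s1)c1cn(-c2ccccc2)nc1-c1ccc(Cl)cc1`, has not been measured yet. It differs from compound 3 in one place: chloro in place of hydrogen on an aromatic carbon.

Among the compounds with values here, one measured step bears directly on this change. Going from compound 1 to compound 2 puts the same chloro in the same place on the shared core, and that step gave a 1.4-fold higher number from compound 1 to compound 2 (0.14 log units; within the scatter). The other step, a 1.2-fold higher number from compound 1 to compound 3 (0.07 log units; within the scatter), swaps a fluoro for a chloro elsewhere and is also within the scatter, which says that the core of compound 3 already carries the change that compound 4 shares with compound 3.

For compound 4 the expectation in this assay is therefore a small rise or no change beyond the scatter, mirroring the step from compound 1 to compound 2: the estimated step is a 1.3-fold higher number from compound 3 to compound 4 (0.10 log units; within the scatter). Compound 4 is estimated at 50000 nM, with a range from 25000 nM to 100000 nM.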

Compound 4, half-maximal inhibitory concentration: 15700 nM
Estimate against measurement, compound 4: 3.2-fold (0.50 log units) above, outside the stated range (below it).
By their numbers in this assay, from the lowest: compound 4; then compounds 1, 3 and 2 (each within the scatter of the next).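

The chloro on the six-membered ring of the fused system, which turns 1,3-benzothiazol-2-yl into 6-chloro-1,3-benzothiazol-2-yl, now has a readable effect in this assay: adding it gives a 2.5-fold lower number from compound 3 to compound 4 (0.40 log units; beyond the scatter), so what it does depends on the group at the other end of the molecule: the same change on two cores in this assay, a 1.4-fold higher number (0.14 log units; within the scatter) from compound 1 to compound 2 and a 2.5-fold lower number (0.40 log units; beyond the scatter) from compound 3 to compound 4, 3.5-fold (0.54 log units) apart, beyond the scatter of two such steps

The other change behaves in the same way, since chloro in place of fluoro gives a 2.9-fold lower number from compound 2 to compound 4 (0.46 log units; beyond the scatter), although it made no readable difference on the core without the added chloro: the same change on two cores in this assay, a 1.2-fold higher number (0.07 log units; within the scatter) from compound 1 to compound 3 and a 2.9-fold lower number (0.46 log units; beyond the scatter) from compound 2 to compound 4, 3.5-fold (0.54 log units) apart, beyond the scatter of two such steps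

The earlier compounds shown here suggested that neither change mattered, whereas the two chloro groups together give a lower number, meaning stronger inhibition on this read-out, than either single change away, so the effects of the two changes cannot simply be added up.

Going by these compounds, whether this dependence is special to chloro stays open, for instance whether a methoxy group or an amine in the same place would also act differently on the two cores. These compounds also leave open whether the same pairing of groups would give a lower number in any other cell type.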